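This account rests on a few compounds, and the source may have more. Where it says the series, first, only, none or still open, it means among the compounds named here.

Of the compounds shown here, two with the same core have been measured in a physicochemical assay for lipophilicity, at pH 7.4; on this read-out lower numbers stand for lower lipophilicity and higher numbers for higher lipophilicity. Compound 1, `CNC(=O)c1cc(C(=O)NC2CC2)cn(Cc2ccc(OC)cc2)c1=O`, gives 3 in this assay. Compound 2, `CNC(=O)c1cc(C(=O)NCCOC)cn(Cc2ccccc2)c1=O`, gives 2.7 in this assay. Among the compounds with values here, the two numbers lie within the usual scatter of each other, so neither compound can be said to stand apart from the other on this read-out; compound 1 is simply the one whose number sits nearest the top of the pair.

The next compound to be measured is compound 3, `CNC(=O)c1cc(C(=O)NC2CC2)cn(Cc2ccccc2F)c1=O`. It differs from compound 1 in one place: 2-fluorophenyl in place of 4-methoxyphenyl on a saturated chain carbon bound to an aromatic nitrogen. Within the data shown here, no measured pair in this set shows a change of this kind, so there is no step in this assay to lean on; what remains is the values of compound 1 and compound 2 and the structural change itself.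

On that basis the step in this assay from compound 1 to compound 3 is expected to be small, a number 0.10 log units higher from compound 1 to compound 3 (within the scatter), and likely not beyond the scatter. Compound 3 is therefore estimated at 3.1 in this assay, with a range from 2.7 to 3.5.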

Compound 3, distribution coefficient: 3
Estimate against measurement, compound 3: 0.10 log units above, within the range that was stated.
By their numbers in this assay, from the lowest: compounds 2, 1 and 3 (each within the scatter of the next).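

Within the data shown here, compound 3 gives the first reading of a change at this one place: in this assay, putting 2-fluorophenyl in place of 4-methoxyphenyl on a saturated chain carbon bound to an aromatic nitrogen brings no change at the digits printed from compound 1 to compound 3 (within the scatter). On paper the swap is not a trivial one, since the group that leaves holds an oxygen and a hydrogen-bond acceptor, the group that enters holds a fluorine and no acceptor, and the names show the substituent at a different number on the ring, yet this read-out does not separate the two compounds. Nothing measured here explains why the number stays where it is.

The swap alters the substituent and its place on the ring at once, so the pair cannot show what either alteration does alone, and two opposite contributions that cancel cannot be told from two that are each negligible. It also leaves open whether this position stays as quiet with a group of another kind, such as a carboxylic acid or a dimethylamino group on the ring, or a chain ending in an amine in place of the ring.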